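This account rests on a few compounds, and the source may have more. Where it says the series, first, only, none or still open, it means among the compounds named here.

Going by the values given here, compound 2 `CC(C)(C)c1ccc(C(=O)NCc2ccc(-c3nnn[nH]3)cc2)cc1` gives 120 nM in an assay on HeLa cells with Bile acid receptor (Homo sapiens) as the target, read by a luciferase reporter, with a stated time of 24 h (a lower number here means that less compound is needed, a higher number that more compound is needed for the effect), the higher of the two numbers measured so far; compound 1 `CC(C)(C)c1ccc(C(=O)NCc2ccc(NS(C)(=O)=O)cc2)cc1` gives 44 nM, and the step of a 2.7-fold higher number from compound 1 to compound 2 (0.44 log units; beyond the scatter) is the only one known. Compound 3 `C[S+]([O-])c1ccc(CNC(=O)c2ccc(C(C)(C)C)cc2)cc1` differs from compound 2 by a group of 3 heavy atoms (1 carbon, 1 oxygen, 1 sulfur; no ring) in place of a group of 5 heavy atoms (1 carbon, 4 nitrogen; one five-membered aromatic ring with 4 hetero atoms), on an aromatic carbon. Among the compounds with values here, the single measured step bears only loosely on this change, as it involved an exchange on the same aromatic carbon but between two groups unlike the one entering here. Compound 3 is therefore expected to land near compound 2 or somewhat higher, a step of a 1.7-fold higher number from compound 2 to compound 3 (0.22 log units; within the scatter). For compound 3 the estimated value is 200 nM, with a range of 60 nM to 700 nM.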

Compound 3, half-maximal effective concentration: 1300 nM
Estimate against measurement, compound 3: 6.5-fold (0.81 log units) below, and the stated range ends below it.
By their numbers in this assay, from the lowest: compound 1; then compound 2; then compound 3.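

The aromatic carbon para to a large group proves more sensitive to exchange than the earlier step showed. In this assay the group of 3 heavy atoms, with 0 hydrogen-bond donors and no ring, gives an 11-fold higher number from compound 2 to compound 3 (1.03 log units; beyond the scatter) and also a 30-fold higher number from compound 1 to compound 3 (1.47 log units; beyond the scatter) on the same core. Both steps are large, so the exchanges at this position are not equivalent. Nothing available accounts for these steps. Going by these compounds, whether a carboxylic acid or an amine on this carbon would fall nearer compound 1 or compound 3 stays open.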